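The compounds below may be only part of what the source reports. "The series", "measured", "known", "first", "only" and "open" are said of these compounds alone.

Compound 1 `O=C1C2CCCCN2C(=O)N1CN1CCN(c2ccccc2)CC1` and compound 2 `COc1ccccc1N1CCN(CN2C(=O)C3CCCCN3C2=O)CC1` share a core with compound 3 `O=C1C2CCCCN2C(=O)N1CN1CCN(c2cccc(Cl)c2)CC1`, the three differing only in the group on the aromatic ring attached to the ring nitrogen. In an assay on isolated protein for binding affinity to Adrenergic receptor alpha-1 (Rattus norvegicus), read by radioligand binding (on this read-out lower numbers stand for stronger inhibition and higher numbers for weaker inhibition), compound 1 gives > 1000 nM, which is a limit of the assay rather than a number. Compound 2 likewise gives > 1000 nM, again a limit. Compound 3 is the only one of the three with an actual number, 135 nM, and so stands as the sole fixed point. The step of an at least 7.4-fold lower number from compound 1 to compound 3 (0.86 log units; beyond the scatter) and the step of an at least 7.4-fold lower number from compound 2 to compound 3 (0.86 log units; beyond the scatter) both bear on the importance of this position, each reaching a number only with chloro present (the limit of > 1000 nM in this assay, at which 2 of the 3 values shown sit). Compound 4 `O=C1C2CCCCN2C(=O)N1CN1CCN(c2cccc(C(F)(F)F)c2)CC1` carries trifluoromethyl in place of chloro on an aromatic carbon. Among the measured compounds shown here, no measured pair covers the exchange of chloro for trifluoromethyl, so the expected step of a 1.1-fold higher number from compound 3 to compound 4 (0.05 log units; within the scatter) from compound 3 to compound 4 is one that stays within the scatter. Compound 4 is therefore expected to give about 150 nM in this assay, between 50 nM and 500 nM.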

Compound 4, inhibition constant: > 1000 nM
Compound 4 was reported as a limit; the forecaster's own chance of this, stated with the estimate: 10%; at least 6.6-fold (0.82 log units) between middle value and limit.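

Chloro and trifluoromethyl are not interchangeable at this place on the ring: in this assay the exchange gives an at least 7.4-fold higher number from compound 3 to compound 4 (0.86 log units; beyond the scatter). Until now, only the comparisons with hydrogen and with the 2-methoxyphenyl compound suggested that chloro mattered; compound 4 shows that simply having a larger group in the same place does not keep a measurable value. The value of compound 4 is a limit of the assay, not a number: the limit of > 1000 nM in this assay, at which 3 of the 4 values shown sit.

Going by these compounds, the step from compound 1 to compound 4 cannot be read, as both ends are limits, so it stays unknown whether trifluoromethyl differs from hydrogen here at all. Also open, on these data alone, is whether other small groups in this place, such as bromo, methyl or a nitrile, would give a number like that of compound 3.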